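Swapping 4-methylphenyl for 2-hydroxyphenyl on a shared core

The source may hold more compounds than are shown below. What is called first, only, known or untested is meant among the compounds shown, and "the series" means these compounds.

Compound 1 `COc1ccc(/C=N/n2c(S)nnc2-c2cnccn2)cc1OC` - 163000 nM
Compound 2 `Sc1nnc(-c2cnccn2)n1/N=C/c1ccc(Cl)cc1Cl` - 206000 nM
Compound 3 `Cc1ccc(/C=N/n2c(S)nnc2-c2cnccn2)cc1` - 156000 nM

These three values come from an ADME assay on NIH3T3 cells (Mus musculus) for cytotoxicity, read by MTT assay, with a stated time of 24 h (a lower number here means a stronger inhibitor, a higher number a weaker inhibitor), and lie close together. In this assay compound 3 gives 156000 nM and stands within the scatter of both compound 1 and compound 2, so these numbers set no order among the three. No two of these compounds differ in one place only, which means that no single change has yet been measured.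

Compound 4 `Oc1ccccc1/C=N/n1c(S)nnc1-c1cnccn1` has still to be tested in this assay and differs from compound 3 in one place. It has 2-hydroxyphenyl in place of 4-methylphenyl on a carbon with a double bond to nitrogen, and the count for that change reads 2-hydroxyphenyl in place of 4-methylphenyl on a carbon with a double bond to nitrogen in full. For the measured compounds named here, no measured compound carries 2-hydroxyphenyl, so the data give no direct guide to this group. The expectation rests only on the close values of compound 1 at 163000 nM and compound 2 at 206000 nM beside compound 3 at 156000 nM in this series. The expected change, a 1.0-fold higher number from compound 3 to compound 4 (0.01 log units; within the scatter), is estimated to stay within the scatter, in neither direction. For compound 4 the estimated value is 160000 nM, with an expected range from 85000 nM to 290000 nM in this assay.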

Compound 4, half-maximal inhibitory concentration: 131000 nM
For compound 4 the middle estimate is 1.2-fold (0.09 log units) above the measured one; measured number inside the range.
By their numbers in this assay, from the lowest: compounds 4, 3, 1 and 2 (each within the scatter of the next).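

For the compounds shown here, the exchange of 4-methylphenyl for 2-hydroxyphenyl, a 1.2-fold lower number from compound 3 to compound 4 (0.08 log units; within the scatter), is the first single change read in this assay, and it stays within the scatter, so this position has now been probed directly and the two groups cannot be told apart on a carbon with a double bond to nitrogen. The entering group carries 1 hydrogen-bond donor and 1 hydrogen-bond acceptor where 4-methylphenyl has none, with the heavy-atom count unchanged, yet this exchange produces no difference that this assay can resolve. Nothing available bears on why this step is as small as it is.

Going by these compounds, one exchange within the scatter does not show that this position is insensitive in general, and it remains open whether a phenyl carrying an amine or a carboxylic acid, or a longer alkyl chain in place of the ring, would give a step beyond the scatter. The compounds shown also leave open whether any single change elsewhere on the shared core would do so, since this is the only step available in this series.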